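Replacing Indol-3-yl with 4-Hydroxy-3-methoxyphenyl on the Hydrazone

The source may hold more compounds than are shown below. What is called first, only, known or untested is meant among the compounds shown, and "the series" means these compounds.

Compound 1 `CN(C)CCn1cnnc1-c1cc(Oc2ccc(NC(=O)N/N=C/c3c[nH]c4ccccc34)cc2F)ccn1` was tested in a functional assay on A549 cells (Homo sapiens) for cytotoxicity, read by MTT assay, with a stated time of 72 h (a lower number here means a stronger inhibitor, a higher number a weaker inhibitor), where compound 1 gives 820 nM. Among the two compounds with a numerical result it stands lowest; its nearest neighbour is compound 2 `COc1ccc(/C=N/NC(=O)Nc2ccc(Oc3ccnc(-c4nncn4CCN(C)C)c3)c(F)c2)c(OC)c1OC`, which in this assay gives 6680 nM. Compound 3 `CN(C)CCn1cnnc1-c1cc(Oc2ccc(NC(=O)N/N=C/c3ccc(O)c(O)c3)cc2F)ccn1` reaches only the assay limit in this assay, > 100000 nM, the line being (the limit of > 100000 nM in this assay, at which 1 of the 3 values shown sits).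

Compound 4 `COc1cc(/C=N/NC(=O)Nc2ccc(Oc3ccnc(-c4nncn4CCN(C)C)c3)c(F)c2)ccc1O` differs from compound 1 in one place: 4-hydroxy-3-methoxyphenyl in place of 1H-indol-3-yl on a carbon with a double bond to nitrogen. Going by the values given here, two measured steps bear on this change, both replacing the same 1H-indol-3-yl on the carbon with a double bond to nitrogen by an oxygen-substituted phenyl. The trimethoxy variant gave an 8.1-fold higher number from compound 1 to compound 2 (0.91 log units; beyond the scatter), and the dihydroxy variant gave an at least 120-fold higher number from compound 1 to compound 3 (2.08 log units; beyond the scatter). Compound 4 carries one hydroxy and one methoxy, so a weakening is expected, plausibly between those two outcomes. Compound 4 is therefore estimated to give 15000 nM, with an expected range from 4000 nM to 60000 nM. That estimate corresponds to an expected 18-fold higher number from compound 1 to compound 4 (1.26 log units; beyond the scatter).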

Compound 4, half-maximal inhibitory concentration: > 100000 nM
Compound 4 gave a limit, no number (the forecaster's own chance of this, stated with the estimate: 20%); middle value at least 6.6-fold (0.82 log units) away from the limit.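

In this assay compound 4 gives a limit and no number, as compound 3 does: the limit of > 100000 nM in this assay, at which 2 of the 4 values shown sit.

Keeping one methoxy beside the hydroxy therefore brings no measurable value back, with an at least 120-fold higher number from compound 1 to compound 4 (2.08 log units; beyond the scatter) and an at least 14-fold higher number from compound 2 to compound 4 (1.17 log units; beyond the scatter). Among the three compounds with an oxygen-substituted phenyl on the carbon with a double bond to nitrogen, both that carry a free hydroxy sit at the limit, and only compound 2, which has none, gives a number.

Going by these compounds, the step between compound 3 and compound 4 cannot be read, as both values are limits, so the effect of methyl in place of hydrogen on that oxygen stays unknown. On these data alone, it also stays open whether an amine in place of the hydroxy, or a phenyl carrying a single methoxy alone, would give a number in this assay.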